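The source may report more compounds than this note shows. Statements on the series, on what has been measured and on what is new or still open speak of the compounds shown alone.

Two compounds share a core and differ only in the group on a carbonyl carbon attached through an amide-type nitrogen. Compound 1 `CCCCc1ccc(CNC(=O)OC(C)(C)C)c(=O)n1Cc1ccc(-c2ccccc2-c2nn[nH]n2)cc1` carries a tert-butoxy group there, and in a functional assay (aorta) for antagonist activity, with Oryctolagus cuniculus as the target (on this read-out lower numbers stand for stronger inhibition and higher numbers for weaker inhibition), compound 1 gives 10 nM. Compound 2 `CCCCc1ccc(CNC(=O)Nc2ccccc2)c(=O)n1Cc1ccc(-c2ccccc2-c2nn[nH]n2)cc1` carries an anilino group in that place, and in this assay compound 2 gives 30 nM. For the measured compounds named here, the only measured step, a 3.0-fold higher number from compound 1 to compound 2 (0.48 log units; beyond the scatter), moves in the direction of weaker inhibition. Compound 2 therefore stands as the higher of the two numbers, with compound 1 as its nearest neighbour at a lower value.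

Compound 3 `CCCCc1ccc(CNC(C)=O)c(=O)n1Cc1ccc(-c2ccccc2-c2nn[nH]n2)cc1` is the next member of the series. Its difference from compound 2 is methyl in place of anilino on a carbonyl carbon. Going by the values given here, no measured step covers this exact exchange; the step of a 3.0-fold higher number from compound 1 to compound 2 (0.48 log units; beyond the scatter) is the only one at the same carbonyl carbon and it was modest. On that basis compound 3 is expected to show a step of a 1.3-fold higher number from compound 2 to compound 3 (0.12 log units; within the scatter), a change of small size whose direction is uncertain. Compound 3 is accordingly estimated at 40 nM in this assay, within a range from 10 nM to 160 nM.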

Compound 3, half-maximal inhibitory concentration: 3 nM
Estimate against measurement, compound 3: 13-fold (1.12 log units) above; the measured number lies below the stated range.
By their numbers in this assay, from the lowest: compound 3; then compound 1; then compound 2.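

At the carbonyl carbon, the exchange of anilino for methyl gives a 10-fold lower number from compound 2 to compound 3 (1.00 log units; beyond the scatter) in this assay, so this place, which had so far shown only a move towards weaker inhibition, can also move towards stronger inhibition. Methyl also outdoes tert-butoxy, with a 3.3-fold lower number from compound 1 to compound 3 (0.52 log units; beyond the scatter) in this assay, which places compound 3 as the strongest inhibitor of the three and compound 2, with its anilino group, as the weakest. The material at hand offers no explanation for these differences.

The exchange from compound 2 to compound 3 removes the six-membered aromatic ring and the hydrogen-bond donor of the anilino group together, so the three compounds cannot show which of the two accounts for the difference, and a benzyl or a methylamino group on the same carbonyl carbon would bear on that question. On these data alone, it also remains open whether methyl is a special case at this carbon or whether a longer chain such as ethyl or propyl, or a methoxy group, would give similar numbers.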